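The source may report more compounds than this note shows. Statements on the series, on what has been measured and on what is new or still open speak of the compounds shown alone.

Compound 1: `CC(C)(CN)C(=O)N1N=CCC1c1ccccc1` gives 1.4 in a physicochemical assay for lipophilicity, read by HPLC, measured as chromatographic lipophilicity, at pH 7.4; on this read-out lower numbers stand for lower lipophilicity and higher numbers for higher lipophilicity.
Compound 2: `O=C(c1ccccc1)N1N=CCC1c1ccccc1` gives 4.6 in this assay.
Compound 3: `O=C(C1CCCC1)N1N=CCC1c1ccccc1` gives 5.4 in this assay.

Among these three, compound 3 stands highest in this assay; its nearest neighbour is compound 2, and the step of a number 0.80 log units higher from compound 2 to compound 3 (beyond the scatter) lies beyond the scatter, while the step of a number 4.00 log units higher from compound 1 to compound 3 (beyond the scatter) is far larger. Compound 4, `O=C(c1cccnc1)N1N=CCC1c1ccccc1`, has not yet been measured. It differs from compound 3 at one place: pyridin-3-yl in place of cyclopentyl on a carbonyl carbon.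

For the measured compounds named here, only one measured step touches this same carbonyl carbon with a ring in place of a ring: a number 0.80 log units higher from compound 2 to compound 3 (beyond the scatter), where a six-membered aromatic ring of carbon gave way to cyclopentyl. The change to compound 4 runs the other way, from cyclopentyl back to a six-membered aromatic ring, and the entering pyridin-3-yl carries a nitrogen and one hydrogen-bond acceptor that phenyl in compound 2 did not. Going by the values given here, no measured compound here holds a nitrogen-containing aromatic ring, so its share is untested. Compound 4 is therefore expected to fall below compound 3 by a step of a number 2.20 log units lower from compound 3 to compound 4 (beyond the scatter), at least as large as the reversal of a number 0.80 log units higher from compound 2 to compound 3 (beyond the scatter) and likely larger. Compound 4 is estimated at 3.2, in the range 2.6 to 3.9.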

Compound 4, distribution coefficient: 2.7
Compound 4: the middle estimate sits 0.50 log units above what was measured; measured number inside the range.
By their numbers in this assay, from the lowest: compound 1; then compound 4; then compound 2; then compound 3.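

At the carbonyl carbon, the ring nitrogen of pyridin-3-yl moves the number in this assay well beyond what the earlier ring-for-ring step showed (a number 1.90 log units lower from compound 2 to compound 4 (beyond the scatter)), a larger step than the one seen between phenyl and cyclopentyl (a number 0.80 log units higher from compound 2 to compound 3 (beyond the scatter)). The exchange of cyclopentyl for pyridin-3-yl is larger still (a number 2.70 log units lower from compound 3 to compound 4 (beyond the scatter)), so the two aromatic rings, phenyl and pyridin-3-yl, no longer sit together at this place, and the ring attached here spans a wider range than compounds 2 and 3 alone suggested. Even so, the open-chain amine of compound 1 remains lowest, with pyridin-3-yl standing clear of it (a number 1.30 log units higher from compound 1 to compound 4 (beyond the scatter)), and nothing at hand accounts for any of these steps.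

Going by these compounds, it remains open whether the fall follows the ring nitrogen wherever it stands, as pyridin-2-yl or pyridin-4-yl on this carbonyl carbon would show. A piperidin-3-yl ring at the same place would tell whether the nitrogen alone carries the step or needs the aromatic ring around it.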